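Cyclopropyl on the weaker stereoisomer: compound 4

The source may hold more compounds than are shown below. What is called first, only, known or untested is meant among the compounds shown, and "the series" means these compounds.

Measured so far:
compound 1 `CC(=O)N[C@@H]1CCCc2c1cncc2N1C(=O)c2ccc(Cl)cc2[C@@H]1C1CC1`, > 30000 nM
compound 2 `CC(=O)N[C@@H]1CCCc2c1cncc2N1C(=O)c2ccc(Cl)cc2[C@@H]1C`, 81 nM
compound 3 `CC(=O)N[C@@H]1CCCc2c1cncc2N1C(=O)c2ccc(Cl)cc2[C@H]1C`, 5140 nM

In an ADME assay on cells for inhibition of cytochrome P450 11B1, mitochondrial (Homo sapiens), read by HTRF (on this read-out higher numbers stand for weaker inhibition and lower numbers for stronger inhibition), compound 1 gives only a limit, > 30000 nM, not a number. Compound 2 gives 81 nM, and compound 3 gives 5140 nM, the highest of the two numbers shown. Compounds 2 and 3 share all atoms and bonds and differ only in configuration, and the step is a 63-fold higher number from compound 2 to compound 3 (1.80 log units; beyond the scatter).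

Compound 4 `CC(=O)N[C@@H]1CCCc2c1cncc2N1C(=O)c2ccc(Cl)cc2[C@H]1C1CC1` has not yet been measured. Compared with compound 3 the change is cyclopropyl in place of methyl on a saturated ring carbon. Among the measured compounds shown here, the one measured step that bears on it is the reverse of this change on the other stereoisomer: an at least 370-fold lower number from compound 1 to compound 2 (2.56 log units; beyond the scatter), a large effect in favour of methyl. Reversing that direction on compound 3, which already stands at the weak end, a large rise in this assay is expected, a 7.8-fold higher number from compound 3 to compound 4 (0.89 log units; beyond the scatter), quite possibly reaching the assay limit as compound 1 did. The estimate for compound 4 is 40000 nM, with a range from 8000 nM to 200000 nM.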

Compound 4, half-maximal inhibitory concentration: 22800 nM
Beside the measured number, compound 4's estimate is 1.8-fold (0.24 log units) above it, within the range that was stated.
By their numbers in this assay, from the lowest: compound 2; then compound 3; then compound 4. At a limit, above all of these: compound 1.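

In this assay, putting cyclopropyl in place of methyl on this saturated ring carbon has only a modest effect in the configuration of compound 3: a 4.4-fold higher number from compound 3 to compound 4 (0.65 log units; beyond the scatter). The earlier compounds shown here showed this change only in the other configuration, where it was far larger, so the size of the step depends on the configuration at this carbon: the same change on two cores in this assay, an at least 370-fold lower number (2.56 log units; beyond the scatter) from compound 1 to compound 2 and a 4.4-fold lower number (0.65 log units; beyond the scatter) from compound 4 to compound 3, at least 83-fold (1.92 log units) apart, beyond the scatter of two such steps A larger group at this carbon is therefore not equally penalised in both stereoisomers, at least for this one pair of groups.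

Compound 1 gives only a limit of the assay, > 30000 nM. On these data alone, with cyclopropyl, the change of configuration gives an at least 1.3-fold lower number from compound 1 to compound 4 (0.11 log units; that floor lies within the scatter), so whether configuration still matters with cyclopropyl stays open. Also open, as far as these compounds go, is how an ethyl or an aminomethyl group would behave on this carbon in each configuration.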